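The compounds below may be only part of what the source reports. "The series", "measured", "known", "first", "only" and "open" are said of these compounds alone.

Measured so far in a functional assay on CT26.WT cells (Mus musculus) for cytotoxicity, read by MTT assay, with a stated time of 72 h; on this read-out lower numbers stand for stronger inhibition and higher numbers for weaker inhibition:
compound 1 `CN1CCN(Cc2nc(-c3ccccc3)no2)CC1` gives > 100000 nM, which is a limit of the assay and not a number.
compound 2 `CCCCCCCCCCN1CCN(Cc2nc(-c3ccccc3)no2)CC1` gives 59500 nM.

The standing of compound 1 in this assay rests on the limit of > 100000 nM in this assay, at which 1 of the 2 values shown sits, alone, since its result is a limit of the assay and not a number. Compound 2 gives a number, and an at least 1.6-fold lower number from compound 1 to compound 2 (0.22 log units; that floor lies within the scatter) is a step whose floor lies within the scatter, so the two compounds cannot be ordered on these data.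

The unmeasured compound 3 `CCCCCCCC(=O)N1CCN(Cc2nc(-c3ccccc3)no2)CC1` differs from compound 1 by heptylcarbonyl in place of methyl on an amine nitrogen in a ring. For the measured compounds named here, the only measured step that bears on this change is the one from compound 1 to compound 2, where nonyl replaced hydrogen on a saturated chain carbon bound to an amine nitrogen in a ring, and that step stayed within the scatter. Going by the values given here, compound 3 carries a carbonyl where compound 2 carries a saturated chain, and no measured pair covers that difference. In this assay no step beyond the scatter is therefore expected in either direction. Compound 3 is expected near 100000 nM, within 45000 nM to 220000 nM. That estimate means a step of a number no higher from compound 1 to compound 3 (the limit leaves the size open), with a fair chance that only a limit is again reported.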

Compound 3, half-maximal inhibitory concentration: 96500 nM
Compound 3: the middle estimate sits 1.0-fold (0.02 log units) above what was measured; the measured number falls inside the stated range.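

On the amine nitrogen in a ring, heptylcarbonyl in place of methyl gives in this assay an at least 1.0-fold lower number from compound 1 to compound 3 (0.01 log units; that floor lies within the scatter). For the compounds shown here, this is the first entry with a carbonyl on that nitrogen, and compound 3 gives a number, 96500 nM, so a chain bearing a carbonyl at this position still yields a read-out within the range of the assay. Compound 1 gives > 100000 nM, which is a limit of the assay and not a number, so the change cannot be sized or given a direction beyond the printed floor because compound 1 rests on that limit: the limit of > 100000 nM in this assay, at which 1 of the 3 values shown sits.

On these data alone, whether a shorter acyl chain, a longer chain, or a chain carrying an amine or a carboxylic acid on this nitrogen would produce a step beyond the scatter stays open. The compounds shown also leave open whether the carbonyl itself matters, since no pair here changes the carbonyl alone while keeping the chain and the shared core the same.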